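From 2-phenylethenyl to 2-chlorophenyl on the shared core

The source may hold more compounds than are shown below. What is called first, only, known or untested is meant among the compounds shown, and "the series" means these compounds.

Among the measured compounds shown here, in a functional assay on HL-60 cells (Homo sapiens) for antiproliferative activity, with a stated time of 72 h (a lower number here means a stronger inhibitor, a higher number a weaker inhibitor), compound 3 (`Nc1ncnn2c([C@@H]3O[C@H](CO)[C@@H](O)[C@H]3O)cc(/C=C/c3ccccc3)c12`) gives 2000 nM as the highest numeric value so far. Compound 1 (`Nc1ncnn2c([C@@H]3O[C@H](CO)[C@@H](O)[C@H]3O)cc(C#CC3CC3)c12`) gives 40 nM in the same read-out. The gap, a 50-fold higher number from compound 1 to compound 3 (1.70 log units; beyond the scatter), is large. Compound 2 (`Nc1ncnn2c([C@@H]3O[C@H](CO)[C@@H](O)[C@H]3O)cc(-c3ccccc3)c12`) stands at > 100000 nM as a limit of the assay. Compound 4 (`Nc1ncnn2c([C@@H]3O[C@H](CO)[C@@H](O)[C@H]3O)cc(-c3ccccc3Cl)c12`) carries 2-chlorophenyl in place of 2-phenylethenyl on an aromatic carbon. Two large measured steps concern phenyl: an at least 50-fold lower number from compound 2 to compound 3 (1.69 log units; beyond the scatter) and an at least 2500-fold higher number from compound 1 to compound 2 (3.39 log units; beyond the scatter) on the other side. Compound 4 stands closest to compound 2, so a large rise is expected in this assay for it. The expected change is a 20-fold higher number from compound 3 to compound 4 (1.30 log units; beyond the scatter) and a report of only a limit is possible. Compound 4 is estimated at 40000 nM within a range of 5000 nM to 100000 nM in this read-out.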

Compound 4, half-maximal inhibitory concentration: > 100000 nM
Compound 4 was reported as a limit; the forecaster's own chance of this, stated with the estimate: 50%; middle value at least 2.5-fold (0.39 log units) from the limit.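

In this assay, 2-chlorophenyl on this aromatic carbon gives an at least 50-fold higher number from compound 3 to compound 4 (1.69 log units; beyond the scatter) and, against the 2-cyclopropylethynyl group, an at least 2500-fold higher number from compound 1 to compound 4 (3.39 log units; beyond the scatter). Compound 4 is reported only as a limit, so both compounds with a six-membered aromatic ring placed directly on this carbon, compound 2 and compound 4, now sit at the limit, whereas compound 1 and compound 3 give numeric values.

From the compounds shown here alone, the step from compound 2 to compound 4 cannot be read, because both are limits: the limit of > 100000 nM in this assay, at which 2 of the 4 values shown sit. What an amine or a longer alkyl chain would give on this carbon remains open.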